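Adding a hydroxy group to a short-lived compound

The source may report more compounds than this note shows. Statements on the series, on what has been measured and on what is new or still open speak of the compounds shown alone.

Measured in an ADME assay on microsomes (Homo sapiens) for metabolic stability; on this read-out higher numbers stand for a longer-lived compound and lower numbers for a shorter-lived compound:
- compound 1 `Cc1c(Oc2ccccc2F)c(OC(C)C)nn1-c1ccc(C2CC2)cn1`: 0.0667 h
- compound 2 `Cc1c(Oc2c(F)cccc2F)c(OC(C)C)nn1-c1ccc(C2CC2)cn1`: 0.1 h

These two values lie within the scatter of each other, so compound 2 stands level with compound 1. Compound 3 `Cc1c(Oc2c(F)cccc2F)c(OC(C)C)nn1-c1ncc(C2CC2)cc1O` has not been measured. It differs from compound 2 by one change: hydroxy in place of hydrogen on an aromatic carbon. Among the compounds with values here, only one measured step is available, a 1.5-fold higher number from compound 1 to compound 2 (0.18 log units; within the scatter). Within the data shown here, that step stayed within the scatter, but it concerns a fluoro group at another place, and no measured compound carries a hydroxy group. It therefore offers only weak guidance, and the data give no reason to expect a step beyond the scatter in this assay, or a firm direction. The expected change is small: a 1.2-fold higher number from compound 2 to compound 3 (0.08 log units; within the scatter). Compound 3 is expected at 0.12 h, with an estimated range of 0.05 h to 0.3 h.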

Compound 3, half-life: 0.633 h
Estimate against measurement, compound 3: 5.3-fold (0.72 log units) below; measured number outside the range, above it.
By their numbers in this assay, from the lowest: compounds 1 and 2 (each within the scatter of the next); then compound 3.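

In this assay, a hydroxy group on the six-membered aromatic ring with 1 nitrogen, ortho to a large group and two atoms from the ring nitrogen, gives a 6.3-fold higher number from compound 2 to compound 3 (0.80 log units; beyond the scatter) and so lengthens the half-life. This is the only step among these compounds that lies beyond the scatter, so this one place on the ring can shift the number where the fluoro change at another place did not. The data shown offer no measurement that explains the rise.

Going by these compounds, whether a methoxy group, an amine or a fluoro group at this same place would shift the number as well remains open, so the step cannot yet be tied to the hydroxy group itself. Also open, on these data alone, is whether the hydroxy group would give a similar step on compound 1.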